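From 4-methylphenyl to 4-methoxyphenyl in an antiproliferative series

The source may hold more compounds than are shown below. What is called first, only, known or untested is meant among the compounds shown, and "the series" means these compounds.

In a functional assay on A549 cells (Homo sapiens) for antiproliferative activity, read by MTT assay, with a stated time of 72 h (on this read-out lower numbers stand for stronger inhibition and higher numbers for weaker inhibition), compound 1 (`COc1ncc(-c2ccc3c(c2)N(c2ccc(C)cc2)C(=O)CO3)cc1NS(=O)(=O)c1ccc(F)cc1`) gives 5870 nM, the lower of the two actual numbers shown. Compound 3 (`Cc1ccc(N2C(=O)COc3ccc(-c4cnc(Cl)c(NS(=O)(=O)c5ccc(F)cc5)c4)cc32)cc1`) gives 30900 nM. Compound 2 (`COc1ccc(N2C(=O)COc3ccc(-c4ccc(O)cc4)cc32)cc1`) gives > 40000 nM, which is a limit of the assay and not a number.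

Compound 4 (`COc1ccc(N2C(=O)COc3ccc(-c4cnc(OC)c(NS(=O)(=O)c5ccc(F)cc5)c4)cc32)cc1`) departs from compound 1 in one place: methoxy in place of methyl on an aromatic carbon. This puts methoxy in place of methyl on an aromatic carbon, para to a large group. Within the data shown here, no measured pair isolates this change. Among the measured compounds shown here, the only measured step is a 5.3-fold higher number from compound 1 to compound 3 (0.72 log units; beyond the scatter), a modest one, with chloro in place of methoxy on an aromatic carbon at a different place in the molecule. It therefore bears on the present change only indirectly, as a guide to how far a single substitution can move the value in this series.

No shift beyond the usual scatter is therefore expected, and the expected step is a 1.2-fold higher number from compound 1 to compound 4 (0.08 log units; within the scatter). For compound 4 the estimated value is 7000 nM, with an expected range of 2200 nM to 22000 nM.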

Compound 4, half-maximal inhibitory concentration: 1350 nM
For compound 4 the middle estimate is 5.2-fold (0.71 log units) above the measured one, and the stated range ends above it.
By their numbers in this assay, from the lowest: compound 4; then compound 1; then compound 3. At a limit, above all of these: compound 2.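

In this assay, the change from 4-methylphenyl to 4-methoxyphenyl gives a 4.3-fold lower number from compound 1 to compound 4 (0.64 log units; beyond the scatter) and so shows that the value responds to a substitution at this position, on the six-membered aromatic ring of carbon only and para to a large group. Among these compounds, the earlier compounds could not show this, as their one measured step, a 5.3-fold higher number from compound 1 to compound 3 (0.72 log units; beyond the scatter) and with chloro in place of methoxy, lies at a different place in the molecule. Nothing given here accounts for the direction or size of the new step.

This single pair leaves open whether the shift is particular to methoxy, as neither an ethoxy group, a hydroxyl nor a dimethylamino group stands at this position among the compounds shown. It also leaves open whether 4-methoxyphenyl would shift the value in the same direction on the chloro-bearing compound 3.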